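The compounds below may be only part of what the source reports. "The series", "measured", "known", "first", "only" and "open" are said of these compounds alone.

In a functional assay on A549 cells (Homo sapiens) for cytotoxicity, read by MTT assay, with a stated time of 48 h (on this read-out higher numbers stand for weaker inhibition and lower numbers for stronger inhibition), three compounds built on a shared core have been tested so far. Compound 1 `COc1cc(-n2c(-c3ccc(O)cc3)c[nH]c2=O)cc(OC)c1OC` gives > 50000 nM, which is a limit of the assay and not a number. Compound 2 `COc1ccc(-c2c[nH]c(=O)n2-c2cc(OC)c(OC)c(OC)c2)cc1N` gives > 50000 nM, which is also a limit. Among the compounds with values here, compound 3 `COc1cc(NC(=O)n2cc(-c3ccc(O)cc3)n(-c3cc(OC)c(OC)c(OC)c3)c2=O)cc(OC)c1OC` gives 2500 nM, the only actual number in the set. The remaining information is the limit of > 50000 nM in this assay, at which 2 of the 3 values shown sit.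

Compound 4 `COc1ccc(-c2cn(C(=O)Nc3cc(OC)c(OC)c(OC)c3)c(=O)n2-c2cc(OC)c(OC)c(OC)c2)cc1` differs from compound 3 in one small way: methyl in place of hydrogen on an oxygen on an aromatic ring. In words, this is methyl in place of hydrogen on an oxygen on an aromatic ring, which turns 4-hydroxyphenyl into 4-methoxyphenyl.

Within the data shown here, only one measured step involves this 4-hydroxyphenyl group: a step that the two limits leave unreadable from compound 1 to compound 2. Since both of its ends are limits, it offers no size to carry over to the new change. With no measured guide to size or direction, the expectation stays anchored on compound 3 at 2500 nM, with no shift beyond the usual scatter and a generous margin on both sides. The expected change is no change at the digits printed from compound 3 to compound 4 (within the scatter). For compound 4 the estimated value is 2500 nM, with an expected range from 500 nM to 15000 nM.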

Compound 4, half-maximal inhibitory concentration: > 50000 nM
Compound 4: only a limit was reported (the forecaster's own chance of this, stated with the estimate: 15%); at least 20-fold (1.30 log units) between middle value and limit.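

In this assay, methyl in place of hydrogen on an oxygen on an aromatic ring gives an at least 20-fold higher number from compound 3 to compound 4 (1.30 log units; beyond the scatter), so this one added carbon is enough to move the compound to clearly weaker inhibition. The value of compound 4, > 50000 nM, is a limit of the assay and not a number. Within the data shown here, this is the first step on this group with a readable size, as the step between compound 1 and compound 2 cannot be read, and compound 4 now joins the compounds at the limit: the limit of > 50000 nM in this assay, at which 3 of the 4 values shown sit.

The compounds shown leave open whether the hydroxy group itself is needed or whether another small group in its place, such as an amine or a fluorine, or a longer chain such as ethoxy, would keep a measurable value. This single step also rests on one pair, with a number at only one end, so it says nothing yet about how the same change behaves elsewhere on the shared core.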